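Replacing the Aryl Carbonyl of Compound 3 with Acetyl

The compounds below may be only part of what the source reports. "The series", "measured", "known", "first", "only" and "open" are said of these compounds alone.

Of the compounds shown here, three sharing one core have been tested in a functional assay on NUGC-3 cells (Homo sapiens) for cytotoxicity, read by sulforhodamine B assay, with a stated time of 72 h; on this read-out higher numbers stand for weaker inhibition of growth and lower numbers for stronger inhibition of growth. Compound 1 `CC(=O)N1c2ccccc2CCC1C(=O)Nc1ccccc1O` gives 49700 nM, compound 2 `CCCCCCCCC(=O)N1c2ccccc2CCC1C(=O)Nc1ccccc1C(F)(F)F` gives 6180 nM, and compound 3 `O=C(Nc1ccccc1C(F)(F)F)C1CCc2ccccc2N1C(=O)c1cccc(Cl)c1` gives 754 nM, the lowest of the three. Among the compounds with values here, the one step that touches the carbonyl substituent, an 8.2-fold lower number from compound 2 to compound 3 (0.91 log units; beyond the scatter), shows the aryl group helping. Compound 4 `CC(=O)N1c2ccccc2CCC1C(=O)Nc1ccccc1C(F)(F)F` reverses that direction: methyl in place of 3-chlorophenyl on a carbonyl carbon. With an acetyl group at that carbonyl, compound 1 sits far higher than compound 3, and the octyl group in compound 2 already lay well above it. A loss is therefore expected, a 27-fold higher number from compound 3 to compound 4 (1.42 log units; beyond the scatter). Compound 4 is estimated at 20000 nM, within 5000 nM to 80000 nM.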

Compound 4, concentration for 50% growth inhibition: > 80000 nM
Compound 4: a limit, no number (the forecaster's own chance of this, stated with the estimate: 15%); middle value at least 4.0-fold (0.60 log units) away from the limit.
By their numbers in this assay, from the lowest: compound 3; then compound 2; then compound 1. At a limit, above all of these: compound 4.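

In this assay, compound 4 gives a limit, not a number: the limit of > 80000 nM in this assay, at which 1 of the 4 values shown sits.

At this carbonyl carbon, methyl falls well behind both larger groups, with an at least 100-fold higher number from compound 3 to compound 4 (2.02 log units; beyond the scatter) and an at least 12-fold higher number from compound 2 to compound 4 (1.11 log units; beyond the scatter). The change from hydroxy to trifluoromethyl stays unresolved, since an at least 1.6-fold higher number from compound 1 to compound 4 (0.20 log units; that floor lies within the scatter) is only a floor.

Still open, as far as these compounds go, is whether an unsubstituted phenyl at this carbonyl would keep the gain seen with 3-chlorophenyl, which would separate the part played by the ring from that of the chlorine. A cyclohexyl group there would likewise test whether the aromatic ring is needed.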